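The source may report more compounds than this note shows. Statements on the series, on what has been measured and on what is new or still open speak of the compounds shown alone.

Compound 1 `CCOC(=O)CSc1nnc(C)n1N1C(=O)c2ccccc2C1=O` and compound 2 `C=CCSc1nnc(-c2cc(OC)c(OC)c(OC)c2)n1N1C(=O)c2ccccc2C1=O` were both tested in a functional assay on PC-3M cells (Homo sapiens) for cytotoxicity, read by MTT assay, with a stated time of 48 h; a lower number here means a stronger inhibitor, a higher number a weaker inhibitor. For compound 1 the assay reports only a limit, > 200000 nM. For compound 2 the result is likewise a limit, > 200000 nM. Compound 2 thus stands at the limit of > 200000 nM in this assay, at which 2 of the 2 values shown sit, with no number of its own. Compound 3 `C#CCSc1nnc(-c2cc(OC)c(OC)c(OC)c2)n1N1C(=O)c2ccccc2C1=O` differs from compound 2 in one place: ethynyl in place of vinyl on a saturated chain carbon bound to a sulfur. For the measured compounds named here, with both measured values at a limit, no measured step is available, and the expected step is a number no higher from compound 2 to compound 3 (the limit leaves the size open), none beyond the scatter. Compound 3 is therefore estimated at 200000 nM, between 50000 nM and 400000 nM, most likely again reported only as a limit.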

Compound 3, half-maximal inhibitory concentration: > 200000 nM
Compound 3 was reported as a limit; the forecaster's own chance of this, stated with the estimate: 80%; the middle value lies on the limit itself.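

Compound 3 is reported in this assay only as a limit, > 200000 nM, as compound 2 is, so no step can be read between compound 2 and compound 3. The compounds shown leave open whether allylsulfanyl and propargylsulfanyl differ at all, since none gives a number of its own: the limit of > 200000 nM in this assay, at which 3 of the 3 values shown sit.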